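A few compounds are considered here, and "the series" means these few. Any claim that something is new, unique, unknown or untested is made for them only; others in the source may bear on it.

In an ADME assay on HepG2 cells (Homo sapiens) for cytotoxicity, read by MTT assay, with a stated time of 7 days (on this read-out lower numbers stand for stronger inhibition and higher numbers for weaker inhibition), two compounds built on the same core have been measured so far. Compound 1 `CC(C)Oc1ccc(C2CC(c3ccc(O)cc3)=NN2C(=O)c2cccnc2)cc1` gives 45400 nM, and compound 2 `COc1ccc(OC)c(C2CC(c3ccc(O)cc3)=NN2C(=O)c2cccnc2)c1` gives 56800 nM. Among the compounds with values here, these two numbers cannot be told apart, so compound 2 stands level with the only other measured compound. Compound 3 `COc1ccc(C2CC(c3ccc(O)cc3)=NN2C(=O)c2cccnc2)cc1` alters compound 2 in a single place, with 4-methoxyphenyl in place of 2,5-dimethoxyphenyl on a saturated ring carbon. Within the data shown here, only one measured step bears on this change, as it also swaps the aryl group on that saturated ring carbon. That step is a 1.3-fold higher number from compound 1 to compound 2 (0.10 log units; within the scatter), so exchanging one alkoxy-bearing phenyl group for another made no measurable difference there. A single step is thin evidence, but it gives no reason to expect a large move in this assay. The expected step is a 1.1-fold lower number from compound 2 to compound 3 (0.06 log units; within the scatter), which would be no real change beyond the scatter. For compound 3, the estimated value is 50000 nM, with an expected range from 25000 nM to 100000 nM.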

Compound 3, half-maximal inhibitory concentration: 42400 nM
For compound 3 the middle estimate is 1.2-fold (0.07 log units) above the measured one; the range from low to high includes it.
By their numbers in this assay, from the lowest: compounds 3, 1 and 2 (each within the scatter of the next).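

In this assay, the aryl group on the saturated ring carbon can now be compared in two further ways: 4-methoxyphenyl in place of 2,5-dimethoxyphenyl gives a 1.3-fold lower number from compound 2 to compound 3 (0.13 log units; within the scatter) and, on the oxygen of the aromatic ring, methyl in place of isopropyl gives a 1.1-fold lower number from compound 1 to compound 3 (0.03 log units; within the scatter). Both steps lie within the scatter, so among these three compounds neither one methoxy group against two nor methyl against isopropyl separates the numbers, and all three stand level. Nothing available explains why these exchanges leave the read-out where it is.

On these data alone, all three compounds carry only alkoxy groups on this phenyl ring, so it remains open what a dimethylamino group, a carboxylic acid or a plain unsubstituted phenyl would do at the same saturated ring carbon. Also open, as far as these compounds go, are whether a longer chain on the oxygen, such as butyl, would stay level with these compounds, and whether the same picture would hold with the 4-hydroxyphenyl or (pyridin-3-yl)carbonyl group replaced.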